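The compounds below may be only part of what the source reports. "The series", "measured", "known", "first", "only" and "open" are said of these compounds alone.

Compound 1 `N=C(N)NS(=O)(=O)c1ccc(N/C(S)=N\c2ccnc3cc(C(F)(F)F)ccc23)cc1`: 24300 nM
Compound 2 `Cc1noc(NS(=O)(=O)c2ccc(N/C(S)=N\c3ccnc4cc(C(F)(F)F)ccc34)cc2)c1C`: 27700 nM
Compound 3 `Cc1cc(C)nc(NS(=O)(=O)c2ccc(N/C(S)=N\c3ccnc4cc(C(F)(F)F)ccc34)cc2)n1`: 29500 nM

All three were tested in a functional assay on HT-1080 cells (Homo sapiens) for antiproliferative activity, read by sulforhodamine B assay, with a stated time of 48 h; a higher number here means a weaker inhibitor, a lower number a stronger inhibitor. Compound 1 carries the lowest of the three numbers, but the gaps to its neighbours are small: a 1.1-fold higher number from compound 1 to compound 2 (0.06 log units; within the scatter) and a 1.2-fold higher number from compound 1 to compound 3 (0.08 log units; within the scatter), both within the scatter, so no real order can be read among these compounds.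

Compound 4 `COc1cc(NS(=O)(=O)c2ccc(N/C(S)=N\c3ccnc4cc(C(F)(F)F)ccc34)cc2)nc(OC)n1` has not yet been measured in this assay. Relative to compound 1 the change is this: a group of 10 heavy atoms (6 carbon, 2 nitrogen, 2 oxygen; one six-membered aromatic ring with 2 hetero atoms) in place of a group of 3 heavy atoms (1 carbon, 2 nitrogen; no ring), on a sulfonamide nitrogen. The two measured steps that bear on it are those from compound 1 to compound 2 and from compound 1 to compound 3, where the same group on the same sulfonamide nitrogen was replaced by an aromatic ring, and the number moved only within the scatter each time. The step from compound 2 to compound 3, a 1.1-fold higher number from compound 2 to compound 3 (0.03 log units; within the scatter), shows that swapping one such ring for another also changed little. The expectation for compound 4 is therefore a step of no size beyond the scatter, a 1.2-fold higher number from compound 1 to compound 4 (0.06 log units; within the scatter). Compound 4 is estimated at 28000 nM, with a range from 14000 nM to 56000 nM.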

Compound 4, half-maximal inhibitory concentration: 29500 nM
Compound 4: the middle estimate sits 1.1-fold (0.02 log units) below what was measured, and the stated range covers the measured number.
By their numbers in this assay, from the lowest: compounds 1, 2, 3 and 4 (each within the scatter of the next).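

In this assay, the 2,6-dimethoxypyrimidin-4-yl group on the sulfonamide nitrogen, with 10 heavy atoms, extends the earlier picture to a larger ring substituent, and the step stays within the scatter (a 1.2-fold higher number from compound 1 to compound 4 (0.08 log units; within the scatter)). Exchanging the earlier rings for this one also leaves the number within the scatter (no change at the digits printed from compound 3 to compound 4 (within the scatter); a 1.1-fold higher number from compound 2 to compound 4 (0.03 log units; within the scatter)), so neither the dimethoxy pattern nor the different point of attachment on the pyrimidine separates compound 4 from compound 3. No measurement offered here explains why these changes leave the number so flat.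

Going by these compounds, whether a non-aromatic group on this nitrogen, such as a longer alkyl chain, an amine or a carboxylic acid, would move the number beyond the scatter remains open. On these data alone, the effect of changes elsewhere on the shared core also remains open.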